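The source may hold more compounds than are shown below. What is called first, only, known or untested is meant among the compounds shown, and "the series" means these compounds.

Measured so far:
- compound 1, `O=C(CCCCCCc1ccccc1)c1nc(-c2ccccn2)no1`: 3 nM; 0.34 nM (2 entries)
- compound 2, `O=C(CCCCCCc1ccccc1)c1nc(-c2cccc(Br)n2)no1`: 0.63 nM

Series notes. Among the compounds with values here, in an assay for inhibition of Fatty-acid amide hydrolase 1 (Rattus norvegicus) (a higher number here means a weaker inhibitor, a lower number a stronger inhibitor), compound 2 gives 0.63 nM, the only number held for it; a further entry gives no single number. Compound 1 shows spread between its own entries, (the several entries of compound 1 in this assay, 3 nM; 0.34 nM (2 entries)), which sets the frame for reading any single value here. Compound 3, `O=C(CCCCCCc1ccccc1)c1nc(-c2cccc(I)n2)no1`, is not yet measured. It differs from compound 2 by iodo in place of bromo on an aromatic carbon. With no measured step of this kind in the series, no change beyond the usual scatter is expected: the step from a 1.1-fold lower number from compound 2 to compound 3 (0.02 log units; within the scatter) is estimated as small in either direction. Compound 3 is expected at about 0.6 nM, within 0.15 nM to 2.5 nM.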

Compound 3, inhibition constant: 1 nM
Compound 3: middle estimate off by 1.7-fold (0.22 log units), on the low side; the range from low to high includes it.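

Going from 6-bromopyridin-2-yl to 6-iodopyridin-2-yl gives the first measured step at this place, next to the ring nitrogen: in this assay it is a 1.6-fold higher number from compound 2 to compound 3 (0.20 log units; within the scatter). This exchange of one halogen for the other therefore produces no readable change. The step is also narrower than the gap already seen for a single compound: the several entries of compound 1 in this assay, 3 nM; 0.34 nM (2 entries)

Compound 1 offers no single number to set against either halogen, so what each halogen adds over the hydrogen there cannot be read. On these data alone, whether an amine or a carboxylic acid at this place would shift the number remains open.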